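Adding a Chlorine to a Tetralin Imidazoline Norepinephrine Ligand

This account rests on a few compounds, and the source may have more. Where it says the series, first, only, none or still open, it means among the compounds named here.

Measured compounds:
compound 1 `C1=C(Cc2c[nH]cn2)CCc2ccccc21` — 794 nM
compound 2 `C1=NCC(CC2CCc3ccccc3C2)N1` — 100 nM

Of the compounds shown here, two have been tested in a functional assay for binding affinity to Norepinephrine transporter (Rattus norvegicus), read by radioligand binding, in the presence of a further agent that is not named here; on this read-out higher numbers stand for weaker inhibition and lower numbers for stronger inhibition. Compound 1 `C1=C(Cc2c[nH]cn2)CCc2ccccc21` gives 794 nM, while compound 2 `C1=NCC(CC2CCc3ccccc3C2)N1` gives 100 nM. Compound 2 therefore stands at the lower, stronger end of the two numbers, and the gap to compound 1 lies beyond the usual scatter of this assay.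

Compound 3 `Clc1cccc2c1CC(CC1CN=CN1)CC2` has not yet been measured. It differs from compound 2 in one place: chloro in place of hydrogen on an aromatic carbon, on an aromatic carbon of a six-membered aromatic ring of carbon only, part of a fused system of two rings, ortho to a fused ring. Among the measured compounds shown here, no comparable step between measured compounds exists here, so the outcome rests on compound 2 alone. A modest move toward stronger inhibition is expected, roughly at the edge of the scatter, as in a 2.0-fold lower number from compound 2 to compound 3 (0.30 log units; within the scatter). Compound 3 is estimated to give 50 nM, within 12 nM to 250 nM.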

Compound 3, inhibition constant: 100 nM
Estimate against measurement, compound 3: 2.0-fold (0.30 log units) below; measured number inside the range.
By their numbers in this assay, from the lowest: compounds 2 and 3 (each within the scatter of the next); then compound 1.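

In this assay, placing chloro in place of hydrogen on an aromatic carbon, ortho to a fused ring, gives no change at the digits printed from compound 2 to compound 3 (within the scatter). Among the compounds shown here, this is the first direct test of a change at this position, and it shows that the position tolerates a chlorine in this assay, with compound 3 not distinguishable from compound 2. No measurement here bears on why the chlorine leaves the reading within the scatter.

The compounds shown leave open whether a fluoro, bromo or methoxy group at this same carbon would also leave the number within the scatter. They also leave open whether chloro would do the same on another carbon of the aromatic ring, or on the core of compound 1.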